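The source may hold more compounds than are shown below. What is called first, only, known or untested is meant among the compounds shown, and "the series" means these compounds.

Measured so far in a functional assay on OVCAR-8 cells (Homo sapiens) for inhibition, read by sulforhodamine B assay, with a stated time of 48 h, tested at 100 uM; on this read-out higher numbers stand for a weaker effect at the one concentration tested and lower numbers for a stronger effect:
compound 1 `COc1cc(Cl)cc(-c2nn(-c3cccc(NC(=O)Nc4ccc(Cl)c(C(F)(F)F)c4)c3)cc2-c2ccncc2)c1` gives -33%
compound 2 `COc1cc(Cl)cc(-c2nn(-c3cccc(NC(=O)Nc4ccc(Cl)c(Cl)c4)c3)cc2-c2ccncc2)c1` gives -9%
compound 3 `COc1cc(Cl)cc(-c2nn(-c3cccc(NC(=O)Nc4cccc(C(F)(F)F)c4)c3)cc2-c2ccncc2)c1` gives -43%

Compound 3 stands at the lowest of the three numbers in this assay. Against compound 1 the step of a number 10 percentage points lower from compound 1 to compound 3 (within the scatter) is within the scatter, so compound 3 and compound 1 cannot be ranked against each other; against compound 2 the step of a number 34 percentage points lower from compound 2 to compound 3 (beyond the scatter) is beyond the scatter. The remaining step, a number 24 percentage points higher from compound 1 to compound 2 (beyond the scatter), is modest.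

Compound 4 `COc1cc(Cl)cc(-c2nn(-c3cccc(NC(=O)c4cccc(C(F)(F)F)c4)c3)cc2-c2ccncc2)c1` is the next entry. It differs from compound 3 by 3-(trifluoromethyl)phenyl in place of (3-(trifluoromethyl)phenyl)amino on a carbonyl carbon. None of the three measured steps bears directly on this change: all of them exchange substituents on an aromatic carbon or the whole aryl group on an amide-type nitrogen, while the carbonyl and its neighbours are kept. For the measured compounds named here, the measured steps show only that changes on that side of the molecule range from within the scatter, as from compound 1 to compound 3, to large, as from compound 2 to compound 3. Going by the values given here, with no direct precedent, a modest step toward a higher number is expected for compound 4, a number 18 percentage points higher from compound 3 to compound 4 (beyond the scatter), with a wide band. Compound 4 is estimated at -25% in this assay, in the range from -55% to 5%.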

Compound 4, a percentage reported as activity, at one concentration (the size of the read-out at that concentration, not a potency): 41%
Compound 4: middle estimate off by 66 percentage points, on the low side, and the stated range ends below it.
By their numbers in this assay, from the lowest: compounds 3 and 1 (each within the scatter of the next); then compound 2; then compound 4.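

In this assay, replacing (3-(trifluoromethyl)phenyl)amino on the carbonyl carbon with 3-(trifluoromethyl)phenyl gives a number 84 percentage points higher from compound 3 to compound 4 (beyond the scatter), so the linking nitrogen position matters far more than any substituent exchange seen earlier, the largest of which was a number 34 percentage points lower from compound 2 to compound 3 (beyond the scatter). The two steps that combine this change with a different aryl substitution, a number 50 percentage points higher from compound 2 to compound 4 (beyond the scatter) and a number 74 percentage points higher from compound 1 to compound 4 (beyond the scatter), run in the same direction, and compound 4 lies beyond the scatter of all three other compounds, with a positive number where they are all negative. No measurement here explains the size of this step.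

The compounds shown leave open whether the step depends on the nitrogen itself, on its hydrogen, or on the spacing it provides, since the leaving group differs from the entering group in all of these at once. A methylene or an ether oxygen in place of the amino nitrogen, or a methylamino link, would help separate these options, and a 3,4-dichlorophenyl or 4-chloro-3-(trifluoromethyl)phenyl group directly on the carbonyl carbon would show whether the aryl substituent order carries over.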